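Removing a Methyl from a Weak Dichloroacetamide

The source may report more compounds than this note shows. Statements on the series, on what has been measured and on what is new or still open speak of the compounds shown alone.

Measured so far:
compound 1, `O=C(Nc1cccc(-c2ccccn2)c1)C(Cl)Cl`: > 50000 nM
compound 2, `Cc1ccccc1-c1cccc(NC(=O)C(Cl)Cl)c1`: 31600 nM

In a functional assay on NCI-H460 cells (Homo sapiens) for cytotoxicity, read by MTT assay, with a stated time of 68 h (a lower number here means a stronger inhibitor, a higher number a weaker inhibitor), compound 1 reaches only the limit of the assay, > 50000 nM, and gives no number. Within the data shown here, compound 2 is the single compound with a number in this assay, 31600 nM, and that number marks a weak inhibitor. Compound 3, `O=C(Nc1cccc(-c2ccccc2)c1)C(Cl)Cl`, differs from compound 2 by hydrogen in place of methyl on an aromatic carbon. Among the measured compounds shown here, no pair of measured compounds shows how this assay responds to such a change, so the step of a 1.3-fold higher number from compound 2 to compound 3 (0.10 log units; within the scatter) is expected to stay within the usual scatter, in no clear direction. Compound 3 is therefore estimated at 40000 nM, with a range from 15000 nM to 100000 nM.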

Compound 3, half-maximal inhibitory concentration: 20200 nM
Compound 3: the middle estimate sits 2.0-fold (0.30 log units) above what was measured, within the range that was stated.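

In this assay, hydrogen in place of methyl gives a 1.6-fold lower number from compound 2 to compound 3 (0.19 log units; within the scatter), so this first direct test shows no clear effect of the methyl on this aromatic carbon. Phenyl in place of pyridin-2-yl gives an at least 2.4-fold lower number from compound 1 to compound 3 (0.39 log units; beyond the scatter), the only step here that lies beyond the scatter. Compound 1 gives a limit and not a number, so this step shows only a minimum size: the limit of > 50000 nM in this assay, at which 1 of the 3 values shown sits.

As far as these compounds go, whether an amine or a carboxylic acid in place of the methyl would change the number remains open. The compounds shown also leave open how a pyridin-3-yl or pyridin-4-yl group would compare with phenyl.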